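Swapping a Dimethylamino for a Propylamino on a Quinazoline-Type Core

This account rests on a few compounds, and the source may have more. Where it says the series, first, only, none or still open, it means among the compounds named here.

Measured compounds:
compound 1, `Cc1ccc2nc(N3CCNC(C)C3)nc(NCc3ccc(C(=O)NC4CCN(Cc5ccc(F)cc5)CC4)cc3)c2c1`, 2000 nM
compound 2, `CN(C)c1nc(NCc2ccc(C(=O)N3CCC(C(=O)NCc4ccc(F)cc4)CC3)cc2)c2ccccc2n1`, 5700 nM

Of the compounds shown here, two have been measured in a functional assay on HCT-116 cells (Homo sapiens) for inhibition, read by luminescence and resazurin assay, with a stated time of 3 days; on this read-out higher numbers stand for weaker inhibition and lower numbers for stronger inhibition. Compound 1 gives 2000 nM in this assay, and compound 2 gives 5700 nM. Of these two numbers compound 2 has the higher one, so it is the weaker inhibitor, and the gap to compound 1 lies beyond the usual scatter of the measurement. The two compounds share little beyond the benzylamine-linked side chain, so their difference cannot be traced to any single change.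

Compound 3, `CCCNc1nc(NCc2ccc(C(=O)N3CCC(C(=O)NCc4ccc(F)cc4)CC3)cc2)c2ccccc2n1`, has not yet been measured. It keeps the whole of compound 2 except for one change: propylamino in place of dimethylamino on an aromatic carbon. The place is on an aromatic carbon of the bicyclic core, between two ring nitrogen atoms.

Going by the values given here, no measured pair shows this change, so there is no direct guide. A small step is expected, with no clear direction beyond the scatter. Compound 3 is therefore estimated at 4000 nM in this assay, with a range from 1500 nM to 12000 nM, which means an expected step of a 1.4-fold lower number from compound 2 to compound 3 (0.15 log units; within the scatter).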

Compound 3, half-maximal inhibitory concentration: 5500 nM
For compound 3 the middle estimate is 1.4-fold (0.14 log units) below the measured one; the measured number falls inside the stated range.
By their numbers in this assay, from the lowest: compound 1; then compounds 3 and 2 (each within the scatter of the next).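

Putting propylamino in place of dimethylamino on this aromatic carbon, between two ring nitrogen atoms, gives a 1.0-fold lower number from compound 2 to compound 3 (0.02 log units; within the scatter) in this assay, so the two compounds cannot be told apart on this read-out. The exchange takes the group from 3 heavy atoms and 0 hydrogen-bond donors to 4 heavy atoms and 1 hydrogen-bond donor, and for this pair that difference in the group leaves the two numbers within the scatter of each other. Nothing measured here explains this result.

On these data alone, what remains open is whether a group of another kind at this position, such as a morpholine ring, a carboxylic acid or a longer chain like hexylamino, would give a step beyond the scatter. Compound 1, at 2000 nM, differs from compound 3 in more than one place, so that pair says nothing about this position, and whether the exchange would read the same way on the core of compound 1 is also unknown.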